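The compounds below may be only part of what the source reports. "The series", "measured", "known", "first", "only" and "open" are said of these compounds alone.

Within the data shown here, compound 2 `COc1cccc(Oc2ccc3c(NCCCNCc4cc(F)ccc4OC)ccnc3c2)c1` is one of three compounds so far measured in a physicochemical assay for solubility, with a stated time of 18 h, at pH 7.4 (on this read-out lower numbers stand for lower solubility and higher numbers for higher solubility), and in this assay compound 2 gives 14500 nM. Compound 1 `COc1ccc(Oc2ccc3c(NCCCNCc4cc(F)ccc4OC)ccnc3c2)cc1` gives 14500 nM, and the step of no change at the digits printed from compound 1 to compound 2 (within the scatter) goes with a 3-methoxyphenyl in place of a 4-methoxyphenyl on an oxygen on an aromatic ring. Among the measured compounds shown here, compound 3 `COc1ccc(F)cc1CNCCCNc1ccnc2cc(CCc3ccccc3)ccc12` gives 4200 nM; the steps of a 3.5-fold lower number from compound 1 to compound 3 (0.54 log units; beyond the scatter) and a 3.5-fold lower number from compound 2 to compound 3 (0.54 log units; beyond the scatter) both concern the same side of the shared core, each exchanging the group there for the one that compound 3 carries. Compound 2 therefore stands level with compound 1, the two together the highest of the three numbers, with compound 3 the furthest away.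

Compound 4 `COc1cccc(Oc2ccc3c(NCCCNCc4ccco4)ccnc3c2)c1` has not yet been measured. Its difference from compound 2 is furan-2-yl in place of 5-fluoro-2-methoxyphenyl on a saturated chain carbon bound to an amine nitrogen. For the measured compounds named here, none of the measured steps touches this part of the molecule: all three alter the group on the other side of the shared core, and the only one that keeps the core's substituent pattern otherwise intact stays within the scatter. There is thus no direct guide for this change, and no step beyond the scatter is expected from it. Compound 4 is estimated at 18000 nM, within 7000 nM to 45000 nM. The expected step is a 1.2-fold higher number from compound 2 to compound 4 (0.09 log units; within the scatter).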

Compound 4, solubility: 14500 nM
Beside the measured number, compound 4's estimate is 1.2-fold (0.09 log units) above it; low and high end bracket the measured number.
By their numbers in this assay, from the lowest: compound 3; then compounds 1, 2 and 4 (each within the scatter of the next).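

In this assay, among these compounds, the only measured change at this end of the molecule, furan-2-yl in place of 5-fluoro-2-methoxyphenyl on a saturated chain carbon bound to an amine nitrogen, gives no change at the digits printed from compound 2 to compound 4 (within the scatter) and so leaves the read-out where it was. The outgoing group has 9 heavy atoms and a six-membered aromatic ring of carbon only, and the incoming one has 5 heavy atoms and a five-membered aromatic ring with 1 hetero atom, so in this pair a clear difference in ring and size comes with no step beyond the scatter. No measurement shown here explains why the number holds across this exchange.

This is a single pair, so it cannot say whether furan-2-yl would behave the same way on a compound carrying 4-methoxyphenoxy or phenethyl on the other side of the shared core. It also leaves open what a plain phenyl, a pyridine ring, a saturated cyclohexyl ring or a simple alkyl chain would do at this position, and whether the fluorine or the methoxy group matters on its own.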